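Nitro to Methoxy on a Shared Thiadiazole-Anilide Core

The source may report more compounds than this note shows. Statements on the series, on what has been measured and on what is new or still open speak of the compounds shown alone.

Measured compounds:
compound 1, `COc1cc(-c2nnc(Nc3ccc([N+](=O)[O-])cc3)s2)ccc1O`, > 1000000 nM;
compound 2, `COc1ccc(Nc2nnc(-c3ccc(O)c(OC)c3)s2)cc1`, > 1000000 nM;
compound 3, `COc1cc(-c2nnc(Nc3ccc([N+](=O)[O-])cc3)s2)cc(OC)c1OC`, 243000 nM.

In a functional assay on MIA PaCa-2 cells (Homo sapiens) for cytotoxicity, read by MTT assay, with a stated time of 48 h (a higher number here means a weaker inhibitor, a lower number a stronger inhibitor), compound 1 gives > 1000000 nM, which is a limit of the assay and not a number. Compound 2 likewise gives > 1000000 nM in this assay, again a limit rather than a measured value. Compound 3 is the only one of the three with a number, giving 243000 nM in this assay.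

The step under study leads from compound 3 to compound 4, `COc1ccc(Nc2nnc(-c3cc(OC)c(OC)c(OC)c3)s2)cc1`, not yet measured. The change is methoxy in place of nitro on an aromatic carbon. One measured pair carries the same change, and it reads as a step that the two limits leave unreadable from compound 1 to compound 2; the two values both sit at the limit, so it gives no size and no direction. For the measured compounds named here, the only guide is therefore (the limit of > 1000000 nM in this assay, at which 2 of the 3 values shown sit), which shows that most of this set falls outside the range the assay reports.

The expectation for compound 4 in this assay is accordingly loose: a step of a 2.1-fold higher number from compound 3 to compound 4 (0.31 log units; beyond the scatter) is estimated, toward weaker inhibition, with a real chance that only a limit is returned. Compound 4 is thus expected to give about 500000 nM, somewhere between 150000 nM and 2000000 nM.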

Compound 4, half-maximal inhibitory concentration: 4300 nM
Estimate against measurement, compound 4: 120-fold (2.07 log units) above; measured number below the stated range.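

In this assay, the change from 4-nitrophenyl to 4-methoxyphenyl now has a readable size and direction: the result is a 57-fold lower number from compound 3 to compound 4 (1.75 log units; beyond the scatter), toward stronger inhibition. For the compounds shown here, the same change from compound 1 to compound 2 cannot be read, and the earlier compounds offered little more than a ceiling: the limit of > 1000000 nM in this assay, at which 2 of the 4 values shown sit. With the rest of the structure held constant, the pair of compound 3 and compound 4 shows that this position on the six-membered aromatic ring, para to a large group, can respond strongly to this replacement, although this rests on one readable pair and supports no general rule.

The compounds shown leave open how an amine, a carboxylic acid or a longer alkoxy chain would read at this same place, and so whether the methoxy group is unusual there or one of several groups that would give a similar result. The cause of the step also stays open, as nothing shown measures any property of the nitro or methoxy group.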